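The source may report more compounds than this note shows. Statements on the series, on what has been measured and on what is new or still open speak of the compounds shown alone.

Measured so far:
compound 1, `N#Cc1c(-c2ccc(Cl)cc2)nc(SCC(=O)Nn2c(COc3ccc(Cl)cc3Cl)nc3ccccc3c2=O)[nH]c1=O`, gives 63.6%;
compound 2, `N#Cc1c(-c2ccc(O)cc2)nc(SCC(=O)Nn2c(COc3ccc(Cl)cc3Cl)nc3ccccc3c2=O)[nH]c1=O`, gives 63.6%;
compound 3, `N#Cc1c(Nc2ccc(Cl)cc2)nc(SCC(=O)Nn2c(COc3ccc(Cl)cc3Cl)nc3ccccc3c2=O)nc1-c1ccccc1`, gives 54.6%.

All three numbers come from a functional assay on the whole organism (strain albino) for inhibition, with Rattus norvegicus as the target, read by paw edema, with a stated time of 1 h, at a dose of 100 mg/kg by the oral route; on this read-out higher numbers stand for more inhibition at the one dose given (going by the name of the read-out) and lower numbers for less inhibition. Compound 1 and compound 2 differ by hydroxy in place of chloro on an aromatic carbon, and this assay records no change at the digits printed from compound 1 to compound 2 (within the scatter). Compound 3 carries a different core; how the core of compound 3 differs from the core of compound 1 is not broken down here. Its number sits nearest to compound 1 and furthest from compound 2, yet both gaps stay within the scatter, so no order among the three can be read.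

Compound 4, `N#Cc1c(Nc2ccc(O)cc2)nc(SCC(=O)Nn2c(COc3ccc(Cl)cc3Cl)nc3ccccc3c2=O)nc1-c1ccccc1`, is not yet measured. It differs from compound 3 by hydroxy in place of chloro on an aromatic carbon, the same change that led from compound 1 to compound 2. Because that earlier change gave no change at the digits printed from compound 1 to compound 2 (within the scatter), the step from compound 3 to compound 4 is expected to be of the same size, namely a number 0.4 percentage points higher from compound 3 to compound 4 (within the scatter). On that basis compound 4 is estimated at 55% in this assay, with a range from 42% to 68%.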

Compound 4, a percentage reported as inhibition, in the whole organism at one dose (the size of the read-out at that dose, not a potency): 72.7%
Compound 4: middle estimate off by 17.7 percentage points, on the low side; measured number outside the range, above it.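

In this assay, hydroxy in place of chloro on an aromatic carbon gives a number 18.1 percentage points higher from compound 3 to compound 4 (beyond the scatter), and the same change does not carry over at one size from one core to the other: the same change on two cores in this assay, no change at the digits printed (within the scatter) from compound 1 to compound 2 and a number 18.1 percentage points higher (beyond the scatter) from compound 3 to compound 4, 18.1 percentage points apart, beyond the scatter of two such steps. In this series, then, a step read on one core is no safe guide to the size of the same step on another, at least across these two pairs. The pairs do not show which difference between the cores separates the two steps, and with a single pair on each core, they do not show how the change would behave on a third core or whether either step would repeat.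

The compounds shown leave open what a methoxy group, an amine or a carboxylic acid in place of the chloro or hydroxy would give on either core. They also leave open whether any such group would follow the step seen on the core of compound 1 or the one seen on the core of compound 3.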